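Changing One Stereocentre: What to Expect for Compound 3

The compounds below may be only part of what the source reports. "The series", "measured", "known", "first", "only" and "open" are said of these compounds alone.

Measured so far in an assay on membranes from liver for displacement of a labelled ligand from Sigma intracellular receptor 2 (Rattus norvegicus), read by scintillation counting, with a stated time of 120 min, tested at 1 uM; on this read-out higher numbers stand for more inhibition at the one concentration tested (going by the name of the read-out) and lower numbers for less inhibition:
compound 1, `NCC[C@H]1CCC[C@@H](c2ccccc2)C1`: 24%
compound 2, `NCC[C@@H]1CCC[C@H](c2ccccc2)C1`: 38%

Compound 2 stands highest of the two numbers, with compound 1 the nearer and only neighbour. Among the measured compounds shown here, the step of a number 14 percentage points higher from compound 1 to compound 2 (beyond the scatter) is the only measured step, and it rests on the fact that compounds 1 and 2 differ only in the configuration as drawn: both stereocentres are inverted, so the two are mirror images.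

Compound 3, `NCC[C@H]1CCC[C@H](c2ccccc2)C1`, has not been measured. Its relation to compound 2 is the two compounds have the same atoms and bonds and differ only in configuration as drawn: 1 of 2 stereo elements differ; a stereocentre at a saturated ring carbon is drawn R in compound 2 and S in compound 3. This is a different kind of change from the measured one: inverting both centres gave a modest rise, whereas here only one centre at a saturated ring carbon is inverted, which makes compound 3 a diastereomer of both measured compounds rather than a mirror image of either. For the measured compounds named here, no measured pair covers such a change, so the measured step gives only a scale, not a direction. Compound 3 is thus expected to show a step of a number 5 percentage points lower from compound 2 to compound 3 (within the scatter) that stays within the usual scatter. Compound 3 is accordingly estimated at 33% in this assay, with a range from 10% to 60%.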

Compound 3, a percentage reported as inhibition, at one concentration (the size of the read-out at that concentration, not a potency): 60%
Beside the measured number, compound 3's estimate is 27 percentage points below it, and the stated range covers the measured number.
By their numbers in this assay, from the lowest: compound 1; then compound 2; then compound 3.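

In this assay, inverting just one stereocentre at a saturated ring carbon raises the number in both pairs where this change can be read, giving a number 22 percentage points higher from compound 2 to compound 3 (beyond the scatter) and a number 36 percentage points higher from compound 1 to compound 3 (beyond the scatter). The diastereomer, compound 3, therefore stands above both mirror images, so the single inversion, whose direction could not be read before, goes upward from either of them, and by a large step from compound 1: the fact that compounds 1 and 3 differ only in the configuration as drawn Nothing enters or leaves in the other pair either, so configuration as drawn is all that separates these numbers: the fact that compounds 2 and 3 differ only in the configuration as drawn

What the compounds shown leave open is how the mirror image of compound 3 would read in this assay, and whether the order of the three would persist at other concentrations, as each number is a single-concentration read-out and not a potency. They also leave open whether the same order would hold with a tertiary amine in place of the primary amine, or with a longer chain carrying it.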